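One Added Carbon on the Methylamino Group

The source may hold more compounds than are shown below. What is called first, only, known or untested is meant among the compounds shown, and "the series" means these compounds.

In a functional assay on the whole organism with Rattus norvegicus as the target (a lower number here means that less compound is needed, a higher number that more compound is needed for the effect), compound 1 `COc1cc(N)c(Cl)cc1C(=O)NCCN(C)Cc1ccccc1C(F)(F)F` gives 30 mg/kg, compound 3 `CCN1CCC(NC(=O)c2cc(Cl)c(NC)cc2OC)C1` gives 10 mg/kg, and compound 2 `CNc1cc(OC)c(C(=O)NC2CCN(Cc3ccccc3)C2)cc1Cl` gives 0.016 mg/kg, the lowest number of the three. Compound 4 `CCNc1cc(OC)c(C(=O)NC2CCN(Cc3ccccc3)C2)cc1Cl` differs from compound 2 by a single change: methyl in place of hydrogen on a saturated chain carbon bound to a nitrogen on an aromatic ring, so methylamino becomes ethylamino. Among the measured compounds shown here, the only measured single change, a 630-fold higher number from compound 2 to compound 3 (2.80 log units; beyond the scatter), is large but lies at another place, so it sets no size here. For the measured compounds named here, no measured step covers this position. A modest rise is therefore expected, the estimated step in this assay being a 2.5-fold higher number from compound 2 to compound 4 (0.40 log units; beyond the scatter). For compound 4 the expected value is 0.04 mg/kg, within a range of 0.01 mg/kg to 0.2 mg/kg.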

Compound 4, dose for half-maximal effect: 0.1 mg/kg
Compound 4: middle estimate off by 2.5-fold (0.40 log units), on the low side; measured number inside the range.
By their numbers in this assay, from the lowest: compound 2; then compound 4; then compound 3; then compound 1.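

In this assay, among the compounds shown here, the earlier compounds held no comparison at the methylamino group, and here its one added carbon gives a 6.3-fold higher number from compound 2 to compound 4 (0.80 log units; beyond the scatter) in a single change. So this position responds to even a small extension, though the step is modest beside a 630-fold higher number from compound 2 to compound 3 (2.80 log units; beyond the scatter) at another place in the molecule. No available measurement explains the rise. Going by these compounds, whether a longer chain such as propyl on this nitrogen would raise the number further remains open, as does the effect of a branched group such as isopropyl.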